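The compounds below may be only part of what the source reports. "The series", "measured", "known", "first", "only" and "open" are said of these compounds alone.

Compound 1, `CC(C)c1ccc(NC(=N)Nc2ccc(C(C)C)cc2)cc1`, gives 242 nM in an assay on membranes from brain (Cavia porcellus) for binding affinity to Sigma non-opioid intracellular receptor 1 (Homo sapiens), read by radioligand binding; on this read-out lower numbers stand for stronger inhibition and higher numbers for weaker inhibition.
Compound 2, `Cc1ccccc1NC(=N)N(C)c1ccccc1C`, gives 6280 nM.
Compound 3, `CN(C(=N)Nc1cccc2ccccc12)c1cccc([N+](=O)[O-])c1`, gives 6260 nM.

Among these three numbers, compound 3 gives the second highest. Within the data shown here, compound 2 gives a number that lies within the usual scatter of the one for compound 3, so the two cannot be told apart on this read-out. Compound 1 gives a number far lower than that of compound 3, a gap well beyond the scatter, so compound 1 inhibits the binding of the radioligand much more strongly than compound 3 does.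

Compound 4, `CN(C(=N)Nc1cccc2ccccc12)c1cccc(N=[N+]=[N-])c1`, has not yet been measured. It differs from compound 3 in one place: azido in place of nitro on an aromatic carbon. Among the measured compounds shown here, no measured pair shows what this exchange does to binding, so the expectation rests on the change itself being a single, small swap while the rest of the molecule stays the same. In this assay the step is expected to be a 1.4-fold lower number from compound 3 to compound 4 (0.14 log units; within the scatter), that is, nothing beyond the scatter. Compound 4 is therefore estimated to give 4500 nM, with a range from 1500 nM to 13000 nM.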

Compound 4, half-maximal inhibitory concentration: 3020 nM
For compound 4 the middle estimate is 1.5-fold (0.17 log units) above the measured one; low and high end bracket the measured number.
By their numbers in this assay, from the lowest: compound 1; then compound 4; then compounds 3 and 2 (each within the scatter of the next).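

Placed on an aromatic carbon meta to a large group, azido in place of nitro gives a 2.1-fold lower number from compound 3 to compound 4 (0.32 log units; beyond the scatter) in this assay. Among these compounds, this is the first pair here that differs in only one place, and it shows that this position responds, if modestly, to an exchange between two groups that each have 3 heavy atoms and no net charge, one built from nitrogen and oxygen and the other from nitrogen alone. Nothing measured here explains why the number moves.

A single exchange at one position cannot show whether an amine, a methoxy group or a carboxylic acid on the same carbon would shift the number further, or in which direction. It also leaves open whether azido in place of nitro would give a similar step on a different core.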